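The source may report more compounds than this note shows. Statements on the series, on what has been measured and on what is new or still open speak of the compounds shown alone.

Compound 1 `CCc1cccc2nc(-c3ccccc3)cc(OC)c12` and compound 2 `CCOc1cc(-c2ccccc2)nc2cccc(CC)c12` share one core. In a functional assay for inhibition, with Homo sapiens as the target (a lower number here means a stronger inhibitor, a higher number a weaker inhibitor), compound 1 gives 80 nM, and in this assay compound 2 gives 140 nM. The change between them, (methyl in place of hydrogen on a saturated chain carbon bound to an oxygen on an aromatic ring), amounts to a 1.8-fold higher number from compound 1 to compound 2 (0.24 log units; within the scatter). Compound 3 `CCc1cccc2c1C(OCC(=O)NC)CC(c1ccccc1)=N2` rests on a different core; the difference between the two cores is not broken down here. In this assay compound 3 gives 1880 nM, beyond the scatter from both compound 1 and compound 2. Compound 4 `CCNC(=O)COC1CC(c2ccccc2)=Nc2cccc(CC)c21` carries the change (methyl in place of hydrogen on a saturated chain carbon bound to an amide-type nitrogen). This is the same kind of change as that between compound 1 and compound 2, but there the saturated chain carbon is bound to an oxygen on an aromatic ring, whereas here it is bound to an amide-type nitrogen. Because the earlier step came to a 1.8-fold higher number from compound 1 to compound 2 (0.24 log units; within the scatter), the new step is expected to come to a 1.5-fold higher number from compound 3 to compound 4 (0.17 log units; within the scatter). Compound 4 is therefore estimated at 2800 nM in this assay, with a likely range from 1200 nM to 7000 nM.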

Compound 4, half-maximal inhibitory concentration: 600 nM
Compound 4: middle estimate off by 4.7-fold (0.67 log units), on the high side; measured number below the stated range.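

In this assay, the change from methylcarbamoyl to ethylcarbamoyl amounts to a 3.1-fold lower number from compound 3 to compound 4 (0.50 log units; beyond the scatter). Set beside the earlier step, this shows that the same change did not give the same result on the two cores: the same change on two cores in this assay, a 1.8-fold higher number (0.24 log units; within the scatter) from compound 1 to compound 2 and a 3.1-fold lower number (0.50 log units; beyond the scatter) from compound 3 to compound 4, 5.5-fold (0.74 log units) apart, beyond the scatter of two such steps It does not show whether the core itself accounts for the gap, as each core offers only one pair and the saturated chain carbon is bound to an oxygen on an aromatic ring in one pair and to an amide-type nitrogen in the other.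

The compounds shown leave open whether propylcarbamoyl or a longer chain in place of ethylcarbamoyl would lower the number further. They also leave open how a carboxylic acid in that place would read.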